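Adding an isopropoxy group while keeping the nitrile

The compounds below may be only part of what the source reports. "The series", "measured", "known", "first", "only" and "open" are said of these compounds alone.

Compound 1 `Cc1ccc2ccc(-c3cccc(C#N)c3)cc2n1` gives 7.7 nM in a functional assay on CHO cells for inhibition of metabotropic glutamate receptor 5 (Rattus norvegicus), read by FLIPR and calcium flux (a lower number here means a stronger inhibitor, a higher number a weaker inhibitor), the lowest of the two plain numbers shown. Compound 2 `Cc1ccc2ccc(-c3cccc(O)c3)cc2n1` gives 19000 nM in this assay, and the change is a 2500-fold higher number from compound 1 to compound 2 (3.39 log units; beyond the scatter). For compound 3 `Cc1ccc2ccc(-c3cccc(C(N)=O)c3)cc2n1` this assay reports only a limit, > 10000 nM. The corresponding change is an at least 1200-fold higher number from compound 1 to compound 3 (3.11 log units; beyond the scatter), again large. Both measured steps remove the cyano group; compound 4 `Cc1ccc2ccc(-c3cc(C#N)cc(OC(C)C)c3)cc2n1` keeps that group and instead carries isopropoxy in place of hydrogen on an aromatic carbon. Going by the values given here, no measured step shows what an added group of this kind does on that ring, so the two large losses give no direct guide, and a step within the scatter is expected: a 1.3-fold higher number from compound 1 to compound 4 (0.11 log units; within the scatter). Compound 4 is thus estimated at 10 nM, within 2 nM to 50 nM.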

Compound 4, half-maximal inhibitory concentration: 310 nM
The estimate for compound 4 lay 31-fold (1.49 log units) below the measured number; measured number above the stated range.
By their numbers in this assay, from the lowest: compound 1; then compound 4; then compound 2.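

In this assay there is a 40-fold higher number from compound 1 to compound 4 (1.60 log units; beyond the scatter) when isopropoxy replaces hydrogen on an aromatic carbon meta to the cyano group. The earlier compounds shown here showed only losses on replacing the nitrile; compound 4 shows that keeping the nitrile does not by itself hold the number of compound 1 once this position carries an added group. Nothing measured here accounts for the size of this loss.

Going by these compounds, whether the loss belongs to isopropoxy itself or to any group at this position stays open. A methoxy group, a fluorine atom or a longer alkoxy chain at the same place would help separate the two.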